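A second ester-bearing chain on the hydantoin ring

This account rests on a few compounds, and the source may have more. Where it says the series, first, only, none or still open, it means among the compounds named here.

Compound 1 `COc1ccc2c(c1)C(=O)N(C[C@@]1(c3cc4ncccc4o3)NC(=O)N(COC(=O)C(C)(C)C)C1=O)C2` stands highest of the three compounds measured in an ADME assay on the whole organism for pharmacokinetics, with Rattus norvegicus as the target, read by LC-MS, at a dose of 10 mg/kg by the oral route (a lower number here means less compound in the circulation, a higher number more compound in the circulation at the dose given), where compound 1 gives 6640 ng.h/mL. Compound 2 `COc1ccc2c(c1)C(=O)N(C[C@@]1(c3cc4ncccc4o3)NC(=O)N(C)C1=O)C2` gives 366 ng.h/mL and compound 3 `COc1ccc2c(c1)C(=O)N(C[C@@]1(c3cc4ncccc4o3)NC(=O)N(C(C)C)C1=O)C2` gives 174 ng.h/mL; the steps are large, an 18-fold lower number from compound 1 to compound 2 (1.26 log units; beyond the scatter) and a 38-fold lower number from compound 1 to compound 3 (1.58 log units; beyond the scatter), while a 2.1-fold lower number from compound 2 to compound 3 (0.32 log units; beyond the scatter) is modest. Compound 4 `COc1ccc2c(c1)C(=O)N(C[C@]1(c3cc4ncccc4o3)C(=O)N(COC(=O)C(C)(C)C)C(=O)N1COC(=O)C(C)(C)C)C2` differs from compound 1 by (((tert-butyl)carbonyl)oxy)methyl in place of hydrogen on an amide-type nitrogen in a ring. The step from compound 1 to compound 2 bears on this change most directly, since it shows how strongly the number fell when the same group was taken away; adding a second one is expected to move the number upward, though by less. Compound 4 is therefore expected to give 9000 ng.h/mL, within 3000 ng.h/mL to 25000 ng.h/mL. The expected step is a 1.4-fold higher number from compound 1 to compound 4 (0.13 log units; within the scatter).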

Compound 4, area under the concentration-time curve: 1920 ng.h/mL
For compound 4 the middle estimate is 4.7-fold (0.67 log units) above the measured one, and the stated range ends above it.
By their numbers in this assay, from the lowest: compound 3; then compound 2; then compound 4; then compound 1.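

In this assay, a second (((tert-butyl)carbonyl)oxy)methyl on the amide-type nitrogen in the ring gives a 3.5-fold lower number from compound 1 to compound 4 (0.54 log units; beyond the scatter) and so adds nothing to the number. The earlier compounds shown here varied only the other ring nitrogen, and this pair shows that the amide hydrogen kept in compound 1 goes with the higher number. Nothing available explains this fall. On these data alone, it remains open how a shorter acetoxymethyl chain, an aminoethyl chain or a carboxymethyl group on this nitrogen would compare with the hydrogen of compound 1.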